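Acetyl to furan-2-yl on the ring oxygen

This account rests on a few compounds, and the source may have more. Where it says the series, first, only, none or still open, it means among the compounds named here.

Three members of the series have numbers in a functional assay on HeLa cells (Homo sapiens) for cytotoxicity; on this read-out lower numbers stand for stronger inhibition and higher numbers for weaker inhibition. Compound 1 `O=C(Oc1ccc2c(c1)C(=O)C=CC2=O)c1ccccc1` gives 19200 nM, compound 2 `CC(=O)Oc1ccc2c(c1)C(=O)C=CC2=O` gives 27700 nM, and compound 3 `C/C=C/C(=O)OC1=CC(=O)c2ccccc2C1=O` gives 37900 nM. Among the compounds with values here, the single one-place step, a 1.4-fold higher number from compound 1 to compound 2 (0.16 log units; within the scatter), exchanges methyl for phenyl on a carbonyl carbon. Compound 2 thus sits within the scatter of compound 1, and its number and that of compound 3 also lie within the scatter of each other; across the three measured compounds nothing separates beyond the noise.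

Compound 4 `O=C1C=CC(=O)c2cc(Oc3ccco3)ccc21` remains unmeasured. Relative to compound 2 the change is furan-2-yl in place of acetyl on an oxygen on an aromatic ring; the acetyl that leaves has no ring, the furan-2-yl that enters brings one five-membered aromatic ring with one hetero atom. Within the data shown here, no measured step bears on this: the only step, methyl to phenyl on a carbonyl carbon, kept the carbonyl in place and was within the scatter. With nothing to point either way, the expectation for compound 4 is a step of a 1.1-fold lower number from compound 2 to compound 4 (0.03 log units; within the scatter) not beyond the scatter. Compound 4 is estimated at 26000 nM, with a range of 8000 nM to 85000 nM.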

Compound 4, half-maximal inhibitory concentration: 17200 nM
The estimate for compound 4 lay 1.5-fold (0.18 log units) above the measured number; the measured number falls inside the stated range.
By their numbers in this assay, from the lowest: compounds 4, 1, 2 and 3 (each within the scatter of the next, the first and the last beyond it).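

In this assay, furan-2-yl in place of acetyl on an oxygen on an aromatic ring gives a 1.6-fold lower number from compound 2 to compound 4 (0.21 log units; within the scatter). The earlier step changed only the group on a carbonyl carbon and kept the carbonyl, whereas this one removes the carbonyl from that oxygen and brings in one five-membered aromatic ring, and the change still stays within the scatter. So, for this pair, the carbonyl on this oxygen is not required for a number of this size, and no evidence is available to explain the result.

As far as these compounds go, it remains open whether any group on this oxygen can move the number beyond the scatter, for example an amine such as 2-aminoethyl, a carboxylic acid such as carboxymethyl, or a longer chain such as hexyl. From the compounds shown here alone, it is also open whether the result extends to other groups bound directly to this oxygen, such as thiophen-2-yl or plain methyl.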